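Cyanoguanidine series: methylsulfanyl to ethylamino, partition coefficient

A few compounds are considered here, and "the series" means these few. Any claim that something is new, unique, unknown or untested is made for them only; others in the source may bear on it.

Compound 1 `CS/C(=N\C#N)N(C)Cc1ccc(Cl)nc1` heads the two numbers available in a physicochemical assay for lipophilicity, using the shake flask method, measured as octanol-water partition, at 23 degrees C (on this read-out higher numbers stand for higher lipophilicity and lower numbers for lower lipophilicity), where compound 1 gives 1.4. Among the compounds with values here, the only other measured member, compound 2 `CN/C(=N\C#N)NCc1ccc(Cl)nc1`, differs from it in more than one place; in this assay compound 2 gives 0.84, a value lying beyond the scatter below compound 1. Within the data shown here, no single-change step between measured compounds exists, so the size of any one alteration is not yet fixed by data.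

Compound 3 `CCN/C(=N\C#N)N(C)Cc1ccc(Cl)nc1` is still unmeasured. It differs from compound 1 by ethylamino in place of methylsulfanyl on a carbon with a double bond to nitrogen. Among the measured compounds shown here, with no measured step to lean on, the expectation rests only on the two numbers above: compound 2, which carries an amino substituent at the same position, sits lower than compound 1, while compound 3 keeps the methyl on the amine nitrogen that compound 2 lacks and carries a longer chain. The step from compound 1 to compound 3 is therefore expected to be small, a number 0.10 log units lower from compound 1 to compound 3 (within the scatter), most likely within the scatter and if anything downward. Compound 3 is estimated at 1.3, with a range from 0.8 to 1.8.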

Compound 3, partition coefficient: 1.02
The estimate for compound 3 lay 0.28 log units above the measured number; low and high end bracket the measured number.
By their numbers in this assay, from the lowest: compounds 2 and 3 (each within the scatter of the next); then compound 1.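

Compound 3 gives the series its first single-change step at this position: in this assay, ethylamino in place of methylsulfanyl on a carbon with a double bond to nitrogen gives a number 0.38 log units lower from compound 1 to compound 3 (beyond the scatter), a modest step beyond the scatter. The number therefore responds to this exchange even though the rest of compound 1 is kept, and it goes down although the entering ethylamino has 3 heavy atoms against 2 for methylsulfanyl, with sulfur leaving, nitrogen entering, and 1 hydrogen-bond donor arriving where methylsulfanyl has 0. Nothing available bears on what lies behind this step.

From the compounds shown here alone, a single exchange cannot separate the contribution of the changed atom from that of the chain, so the share of each in this step remains open. A dimethylamino, a propylamino or a methoxy group on the same carbon, with the core of compound 1 otherwise kept, would show whether the step depends on the hydrogen on the entering nitrogen, on chain length or on the atom attached to that carbon.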